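The source may report more compounds than this note shows. Statements on the series, on what has been measured and on what is new or still open speak of the compounds shown alone.

Measured so far:
Compound 1 `COc1ccc(C2=C(c3ccc(SC)cc3)CC3CCCN3C2=O)cc1O`: 6000 nM
Compound 2 `COc1ccc(C2=C(c3ccc(SC)cc3)CC3CCCN3C2=O)cc1OC(=O)CNC(=O)OC(C)(C)C`: 10000 nM

In a functional assay on DU-145 cells (Homo sapiens) for cytotoxicity (on this read-out higher numbers stand for weaker inhibition of growth and lower numbers for stronger inhibition of growth), compound 2 stands at 10000 nM, within the scatter of compound 1. Compound 3 `COc1ccc(C2=C(c3ccc(SC)cc3)CC3CCCN3C2=O)cc1OC(=O)C1CCCN1C(=O)OC(C)(C)C` carries 1-(tert-butoxycarbonyl)pyrrolidin-2-yl in place of ((tert-butoxycarbonyl)amino)methyl on a carbonyl carbon. Going by the values given here, the only measured step that bears on this change is a 1.7-fold higher number from compound 1 to compound 2 (0.22 log units; within the scatter), which lies within the scatter. It involves the same kind of attachment on the oxygen on the aromatic ring, and the ring in the new group has not been tested. No step beyond the scatter is therefore expected, and the estimated step is a 1.1-fold lower number from compound 2 to compound 3 (0.05 log units; within the scatter). The expected value for compound 3 is 9000 nM, with an estimated range of 4000 nM to 22000 nM.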

Compound 3, concentration for 50% growth inhibition: 5000 nM
Estimate against measurement, compound 3: 1.8-fold (0.26 log units) above, within the range that was stated.
By their numbers in this assay, from the lowest: compounds 3, 1 and 2 (each within the scatter of the next).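

In this assay, 1-(tert-butoxycarbonyl)pyrrolidin-2-yl on the carbonyl carbon in place of ((tert-butoxycarbonyl)amino)methyl gives a 2.0-fold lower number from compound 2 to compound 3 (0.30 log units; within the scatter), so this position takes a five-membered non-aromatic ring and the loss of the hydrogen-bond donor without a step beyond the scatter. No evidence on hand bears on this result. Open, going by these compounds, is whether a free amine in place of either tert-butoxycarbonyl-bearing group would give a step beyond the scatter. On these data alone, a carboxylic acid or a longer chain on the same carbonyl carbon remains equally open.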